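Compound 3: one more methoxy on the series

The source may hold more compounds than are shown below. What is called first, only, known or untested is meant among the compounds shown, and "the series" means these compounds.

Measured in an ADME assay on BJ cells (Homo sapiens) for cytotoxicity, read by MTT assay, with a stated time of 72 h; a higher number here means a weaker inhibitor, a lower number a stronger inhibitor:
- compound 1 `COc1ccc(CNc2ncnc3c2ncn3C2CCCCO2)c(OC)c1` gives > 25000 nM
- compound 2 `COc1ccc(CNc2ncnc3c2ncn3C2CCCCO2)cc1OC` gives > 100000 nM

Compound 2 stands at > 100000 nM, which is a limit and not a number. Compound 1 gives > 25000 nM, also a limit. Among the measured compounds shown here, no order between these two compounds can be read from the two limits, and no measured step is available to guide the next one.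

Compound 3 `COc1cc(OC)c(OC)cc1CNc1ncnc2c1ncn2C1CCCCO1` differs from compound 2 by methoxy in place of hydrogen on an aromatic carbon, ortho to a large group, meta to a methoxy group and para to a methoxy group (methoxy in place of hydrogen on an aromatic carbon).

No number has yet been seen for this series in this assay, so only a weak expectation is possible: little change, or a modest move toward stronger inhibition, and most likely another limit. The expected change is an at least 1.6-fold lower number from compound 2 to compound 3 (0.22 log units; that floor lies within the scatter), and this estimate is set against a limit rather than a number. Compound 3 is estimated at 60000 nM, with an expected range of 20000 nM to 100000 nM.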

Compound 3, half-maximal inhibitory concentration: > 100000 nM
Compound 3: no number, only a limit; the forecaster's own chance of this, stated with the estimate: 75%; middle value at least 1.6-fold (0.22 log units) from the limit.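

Among the compounds shown here, compound 1, compound 2 and compound 3 all stand as limits in this assay, and no step from compound 1 or compound 2 to compound 3 can be read. The compounds shown leave open whether methoxy in place of hydrogen on an aromatic carbon changes the read-out at all: none of them gives a number.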